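Three Amide Limits and a Methoxyphenyl Newcomer

The source may hold more compounds than are shown below. What is called first, only, known or untested is meant among the compounds shown, and "the series" means these compounds.

In an assay for inhibition of HSP60/HSP10 (Homo sapiens), with a stated time of 60 min (a lower number here means a stronger inhibitor, a higher number a weaker inhibitor), the three measured compounds stand as follows:
Compound 1 `O=C(Nc1ccc(Sc2nc3ccccc3s2)c(Cl)c1)c1cc(Br)cc(Br)c1` gives only a limit, > 100000 nM.
Compound 2 `COc1ccc(Br)cc1C(=O)Nc1ccc(Sc2nc3ccccc3s2)cc1` gives only a limit, > 100000 nM.
Compound 3 `O=C(Nc1ccc(Sc2nc3ccccc3s2)cc1)c1cc(Br)cc(Br)c1` gives only a limit, > 100000 nM.

All three values sit at the limit of > 100000 nM in this assay, at which 3 of the 3 values shown sit, so compound 3 has no number to place it, only the limit. The steps a step that the two limits leave unreadable from compound 1 to compound 3 and a step that the two limits leave unreadable from compound 2 to compound 3 cannot be read for the same reason. Compound 4 `COc1ccccc1C(=O)Nc1ccc(Sc2nc3ccccc3s2)cc1` differs from compound 3 in one place: 2-methoxyphenyl in place of 3,5-dibromophenyl on a carbonyl carbon. Going by the values given here, only the step from compound 2 to compound 3 bears on this change, and its size is unreadable, so no direction or size beyond the scatter can be foreseen in this assay. Compound 4 is therefore expected to give 150000 nM, within 40000 nM to 600000 nM, most likely again as a limit. The expected step is a step that the limit leaves unreadable from compound 3 to compound 4.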

Compound 4, half-maximal inhibitory concentration: > 100000 nM
Compound 4 gave a limit, no number; the forecaster's own chance of this, stated with the estimate: 85%; the middle value is on the limit's open side.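

Going by these compounds alone, compound 4 gives only a limit in this assay, as do compound 2 and compound 3, and no new step among them can be read. The compounds shown leave open whether any single change would yield a measurable value.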